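Carboxy for cyano on the benzoyl hydrazide of compound 1

The source may report more compounds than this note shows. Statements on the series, on what has been measured and on what is new or still open speak of the compounds shown alone.

Compound 1 `N#Cc1ccc(C(=O)NNc2c(Br)cccc2Br)cc1` is one of three hydrazides in this set with numbers. In a toxicity assay on MDCK cells (Canis lupus familiaris) for cytotoxicity, read by CCK-8 assay, with a stated time of 48 h (a higher number here means that more compound is tolerated, a lower number that less compound is tolerated), compound 1 reaches only the limit > 100000 nM and gives no number. Compound 1 thus stands at the limit of > 100000 nM in this assay, at which 2 of the 3 values shown sit, so its own position within the set cannot be ranked. Compound 2 `O=C(NNc1c(Br)cccc1Br)c1cccnc1` also stops at the limit > 100000 nM in this assay. Within the data shown here, compound 3 `CCOc1ccc(C(=O)NNc2c(Br)cc(Br)cc2Br)cc1` is the only member with a number, 54800 nM in this assay. No two of these compounds differ in a single place, so no measured step is available for comparison.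

The unmeasured compound 4 `O=C(O)c1ccc(C(=O)NNc2c(Br)cccc2Br)cc1` differs from compound 1 by carboxy in place of cyano on an aromatic carbon. The change exchanges one small polar group for another of similar size on the same aromatic carbon, and nothing in the set links such an exchange to a change in this assay. The expected step of a number no higher from compound 1 to compound 4 (the limit leaves the size open) is none beyond the scatter, in either direction. For compound 4 the estimate in this assay is 100000 nM, with a range from 40000 nM to 250000 nM, and the measurement is expected most likely to end again at the limit rather than give a number.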

Compound 4, half-maximal cytotoxic concentration: > 100000 nM
Compound 4: no number, only a limit (the forecaster's own chance of this, stated with the estimate: 70%); the middle value sits exactly at the limit.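

In this assay compound 4 stops at the limit > 100000 nM and gives no number, like compound 1, so no step between compound 1 and compound 4 can be read: the limit of > 100000 nM in this assay, at which 3 of the 4 values shown sit.

The compounds shown leave open whether carboxy in place of cyano changes the result in this assay at all.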